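Replacing Pentyl with 2-Methoxyphenyl on an Unresponsive Amide

The source may report more compounds than this note shows. Statements on the series, on what has been measured and on what is new or still open speak of the compounds shown alone.

Compound 1, `C=CC1=C(C(=O)Nc2ccccc2OC)C(c2ccc(F)cc2)OC1`: > 100000 nM
Compound 2, `C=CC1=C(C(=O)NCCCCC)C(c2ccc(OC)cc2)OC1`: > 100000 nM

Of the compounds shown here, two sharing one core have been tested in a functional assay on SW480 cells (Homo sapiens) for cytotoxicity, read by MTT assay, with a stated time of 24 h; a lower number here means a stronger inhibitor, a higher number a weaker inhibitor. For compound 1 the read-out is a limit of the assay and not a number, > 100000 nM. Compound 2 likewise gives only a limit, > 100000 nM. Among the measured compounds shown here, compound 2 thus stands at the limit of > 100000 nM in this assay, at which 2 of the 2 values shown sit, and the one further value shown is a limit as well, so no step between measured compounds can be drawn.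

Compound 3, `C=CC1=C(C(=O)Nc2ccccc2OC)C(c2ccc(OC)cc2)OC1`, remains to be measured in this assay. It differs from compound 2 by 2-methoxyphenyl in place of pentyl on an amide-type nitrogen. Compound 1 already carries 2-methoxyphenyl on its amide nitrogen and gives only a limit in this assay, > 100000 nM. With both measured values at the limit, no step beyond the scatter is expected; the estimated step is a number no higher from compound 2 to compound 3 (the limit leaves the size open). Compound 3 is therefore expected to give about 100000 nM, within a range from 30000 nM to 300000 nM, most probably reported once more as a limit rather than a number.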

Compound 3, half-maximal inhibitory concentration: > 100000 nM
Compound 3: a limit, no number (the forecaster's own chance of this, stated with the estimate: 80%); the middle value lies on the limit itself.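

In this assay compound 3 gives > 100000 nM as a limit and not a number. The steps to compound 3 from compound 2 and from compound 1 cannot be read, and all three compounds share the same limit: the limit of > 100000 nM in this assay, at which 3 of the 3 values shown sit.

The compounds shown leave open how far each lies from that limit, and whether any change on the shared core gives a measurable value.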